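Shifting the amino group: from compound 2 to compound 4

The source may report more compounds than this note shows. Statements on the series, on what has been measured and on what is new or still open speak of the compounds shown alone.

In a functional assay on FM3A cells (Mus musculus) for cytotoxicity, read by cell counting, with a stated time of 2 days (a higher number here means a weaker inhibitor, a lower number a stronger inhibitor), compound 2 `Nc1ccc(/C=C2\SC(=O)N(Cc3ccc(Cl)cc3)C2=O)cc1` gives 60000 nM, the lowest number shown, though its neighbours sit within the scatter of it. Compound 1 `CC(C)(C)c1ccc(CN2C(=O)S/C(=C\c3ccc(N)cc3)C2=O)cc1` gives 80000 nM, and compound 3 `CN1C(=O)S/C(=C\c2ccc(N)cc2)C1=O` gives 107000 nM. The two measured steps, a 1.3-fold lower number from compound 1 to compound 2 (0.12 log units; within the scatter) and a 1.8-fold higher number from compound 2 to compound 3 (0.25 log units; within the scatter), each stay within the scatter and concern only the group on the ring nitrogen. Compound 4 `Nc1cccc(/C=C2\SC(=O)N(Cc3ccc(Cl)cc3)C2=O)c1` differs from compound 2 by 3-aminophenyl in place of 4-aminophenyl on a double-bonded chain carbon bound to a double-bonded ring carbon. Within the data shown here, no measured step touches the aminophenyl part, so nothing measured bears directly on this change. For compound 4 the expected step of no change at the digits printed from compound 2 to compound 4 (within the scatter) is therefore one that stays within the scatter. Compound 4 is estimated at 60000 nM, with a likely range from 30000 nM to 130000 nM.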

Compound 4, half-maximal inhibitory concentration: 246000 nM
Compound 4: the middle estimate sits 4.1-fold (0.61 log units) below what was measured, and the stated range ends below it.
By their numbers in this assay, from the lowest: compounds 2, 1 and 3 (each within the scatter of the next); then compound 4.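

In this assay, among these compounds, the aminophenyl part proves sensitive: moving the amino group gives a 4.1-fold higher number from compound 2 to compound 4 (0.61 log units; beyond the scatter), the first step here beyond the scatter, while the earlier changes on the ring nitrogen stayed within it. The two groups have the same atoms, so the way they are joined alone separates compound 2 from compound 4. No evidence at hand accounts for this step. On these data alone, it remains open whether the same shift would give a similar step in compound 1 or compound 3, and whether a hydroxyl or a carboxylic acid could replace the amino group.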